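This account rests on a few compounds, and the source may have more. Where it says the series, first, only, none or still open, it means among the compounds named here.

Compound 1 `CCOC(=O)c1oc2ccc(N(Cc3ccccc3)S(=O)(=O)c3ccc(C)cc3)cc2c1C`: in a functional assay on HCT-116 cells (Homo sapiens) for inhibition, read by MTT assay, with a stated time of 72 h (a higher number here means a weaker inhibitor, a lower number a stronger inhibitor), compound 1 gives > 40000 nM, which is a limit of the assay.
Compound 2 `CCOC(=O)c1oc2ccc(N(Cc3ccccc3)S(=O)(=O)c3ccc(OC)cc3)cc2c1C`: compound 2 gives > 40000 nM, again a limit.
Compound 3 `CCOC(=O)c1oc2ccc(N(Cc3ccccc3)S(=O)(=O)c3cccc(Cl)c3)cc2c1C`: compound 3 gives > 40000 nM, also a limit.

All three values sit at the limit of > 40000 nM in this assay, at which 3 of the 3 values shown sit, so compound 3 stands at the same limit as the other two and no ordering among them can be read. The steps a step that the two limits leave unreadable from compound 1 to compound 2, a step that the two limits leave unreadable from compound 1 to compound 3 and a step that the two limits leave unreadable from compound 2 to compound 3 are all unreadable for the same reason. Compound 4 `CCOC(=O)c1oc2ccc(N(Cc3ccccc3)S(=O)(=O)c3ccc(F)cc3)cc2c1C` differs from compound 3 by 4-fluorophenyl in place of 3-chlorophenyl on a sulfonyl sulfur. Every measured swap on the sulfonyl sulfur left the value at the limit of > 40000 nM in this assay, at which 3 of the 3 values shown sit, and no step beyond the scatter is expected here either: the step from compound 3 to compound 4 is estimated as a step that the limit leaves unreadable from compound 3 to compound 4. Compound 4 is therefore expected to give 60000 nM in this assay, with a range of 25000 nM to 200000 nM, most probably reported once more only as a limit.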

Compound 4, half-maximal inhibitory concentration: 33100 nM
Estimate against measurement, compound 4: 1.8-fold (0.26 log units) above, and the stated range covers the measured number.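

Among the compounds shown here, with 4-fluorophenyl on the sulfonyl sulfur, compound 4 gives 33100 nM in this assay, the first number in this set that is a measured value and not a limit. Against the earlier compounds this gives an at least 1.2-fold lower number from compound 3 to compound 4 (0.08 log units; that floor lies within the scatter), an at least 1.2-fold lower number from compound 2 to compound 4 (0.08 log units; that floor lies within the scatter) and an at least 1.2-fold lower number from compound 1 to compound 4 (0.08 log units; that floor lies within the scatter). Each of these floors lies within the scatter, so no real gain over those compounds is established: the limit of > 40000 nM in this assay, at which 3 of the 4 values shown sit.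

As far as these compounds go, what stays open is whether a different group on the sulfonyl sulfur, such as a phenyl ring carrying an amine or a carboxylic acid, would give a step beyond the scatter.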